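Swapping the amide aryl group in a dopamine D4 agonist series

The source may report more compounds than this note shows. Statements on the series, on what has been measured and on what is new or still open speak of the compounds shown alone.

Compound 1 `Cc1cc(C(=O)NCN2CCC(c3cccc[n+]3[O-])CC2)ccc1F` and compound 2 `Cc1cccc(C(=O)NCN2CCC(c3nccs3)CC2)c1` share a core and differ in the aromatic group attached to the carbonyl. In a functional assay on HEK293 cells for agonist activity at D(4) dopamine receptor (Homo sapiens), read by FLIPR (on this read-out lower numbers stand for smaller maximal responses and higher numbers for larger maximal responses), compound 1 gives 67%, the lower of the two numbers measured, while compound 2 gives 71%; these two values lie within the scatter of each other, so nothing can be said about an order between them. Compound 3 `O=C(NCN1CCC(c2cccc[n+]2[O-])CC1)c1cnccc1Cl` has not been measured. It differs from compound 1 in one place: 4-chloropyridin-3-yl in place of 4-fluoro-3-methylphenyl on a carbonyl carbon. Going by the values given here, no measured pair isolates this kind of change, so the size of its effect on the maximal response is unknown. The step from compound 1 to compound 3 is expected to be small, a number 5 percentage points lower from compound 1 to compound 3 (within the scatter), most likely not beyond the scatter. Compound 3 is therefore estimated to give 62%, in a range from 40% to 82%.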

Compound 3, largest response reached (reported as efficacy), in percent of the reference or control that the assay uses: 44%
For compound 3 the middle estimate is 18 percentage points above the measured one; measured number inside the range.
By their numbers in this assay, from the lowest: compound 3; then compounds 1 and 2 (each within the scatter of the next).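

In this assay, going by these compounds alone, the aromatic group on the carbonyl carbon proves able to shift the maximal response: 4-chloropyridin-3-yl in place of 4-fluoro-3-methylphenyl gives a number 23 percentage points lower from compound 1 to compound 3 (beyond the scatter) and this is the only step in the set that can be read. The earlier compounds shown here could not show this, since compound 1 and compound 2 differ in more than one place and their values lie within the scatter. Nothing at hand says why the response falls with this change.

As far as these compounds go, this one step swaps the ring carbon for a ring nitrogen, fluorine for chlorine and removes the methyl group all at once, so the share of each remains open. A 4-chlorophenyl or an unsubstituted pyridin-3-yl group at the same place would separate the ring nitrogen from the chlorine.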